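The compounds below may be only part of what the source reports. "The series", "measured", "known", "first", "only" and "open" are said of these compounds alone.

In a functional assay on T-24 cells (Homo sapiens) for cytotoxicity, read by MTT assay, with a stated time of 24 h (on this read-out lower numbers stand for stronger inhibition and higher numbers for weaker inhibition), compound 2 `C[C@@H]1C(=O)[C@H]2C[C@]1(O)CC1=C2[C@]2(C)CCC[C@](C)(CO)[C@H]2CC1` gives only a limit, > 50000 nM. Compound 3 `C[C@@H]1C(=O)[C@H]2C[C@]1(O)CC1=C2[C@]2(C)CCCC(C)(C)[C@H]2CC1` likewise gives only a limit in this assay, > 50000 nM. Compound 1 `C=C1C(=O)[C@H]2C[C@]1(O)CC1=C2[C@]2(C)CCC[C@](C)(CO)[C@H]2CC1` has no result in this assay: "not determined" (no result reported). So compound 2 stands at a limit, with one further value also a limit and one further entry without a number. The one step shown, a step that the two limits leave unreadable from compound 2 to compound 3, joins two limits and cannot be read; the only evidence is the limit of > 50000 nM in this assay, at which 2 of the 3 values shown sit, where two of the three entries sit.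

Compound 4 `C[C@@H]1C(=O)[C@H]2C[C@]1(O)CC1=C2[C@]2(C)CCC[C@](C)(C=O)[C@H]2CC1` differs from compound 2 by formyl in place of hydroxymethyl on a saturated ring carbon. For the measured compounds named here, no measured step bears on an exchange of hydroxymethyl for formyl, and the step from compound 2 to compound 3, which changes a different group, gives no size. The numbers therefore offer no footing for a shift in either direction beyond the scatter, and the expectation for compound 4 is that it stays near where compound 2 stands, with a fair chance that this assay again reports only a limit. The expected step of an at least 1.2-fold lower number from compound 2 to compound 4 (0.09 log units; that floor lies within the scatter) is therefore small. Compound 4 is expected to give about 40000 nM, in the range 10000 nM to 120000 nM.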

Compound 4, half-maximal inhibitory concentration: > 50000 nM
Compound 4 was reported as a limit (the forecaster's own chance of this, stated with the estimate: 60%); middle value at least 1.2-fold (0.09 log units) from the limit.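

For the compounds shown here, compound 2 and compound 4 both give only limits in this assay, so no step between them can be read. The compounds shown leave open whether formyl in place of hydroxymethyl changes cytotoxicity at all, since the evidence stops at one shared limit: the limit of > 50000 nM in this assay, at which 3 of the 4 values shown sit.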